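The source may hold more compounds than are shown below. What is called first, only, known or untested is meant among the compounds shown, and "the series" means these compounds.

Three compounds sharing one core were measured in a functional assay on the whole organism (strain Swiss albino) for inhibition, with Mus musculus as the target, in the formalin test, with stated times of 30 min and 5 min, at a dose of 100 mg/kg; on this read-out lower numbers stand for less inhibition and higher numbers for more inhibition at the one dose given (going by the name of the read-out). Compound 1 `CCN1CCc2c(c(C)nn2C(=O)Nc2ccc(Br)cc2)C1` gives 1.7% in this assay. Compound 2 `CCN1CCc2c(c(C)nn2C(=O)Nc2c(C)cccc2C)C1` gives 12.2%. Compound 3 `CCN1CCc2c(c(C(C)(C)C)nn2C(=O)Nc2ccc(Br)cc2)C1` gives 0%, the lowest of the three numbers; its nearest neighbour is compound 1, whose number stands within the scatter of it, and its furthest is compound 2, whose number lies beyond the scatter above it. The one step joining two of these compounds that differ in a single place is a number 1.7 percentage points lower from compound 1 to compound 3 (within the scatter), a change on an aromatic carbon that left the read-out within the scatter.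

Compound 4 `CCN1CCc2c(c(C(C)(C)C)nn2C(=O)Nc2c(C)cccc2C)C1` is not yet measured. It differs from compound 3 by 2,6-dimethylphenyl in place of 4-bromophenyl on an amide-type nitrogen. Within the data shown here, no measured step matches this change directly. Among the measured compounds shown here, compound 1 and compound 2 differ in the same way at the amide nitrogen, though on the core bearing methyl rather than tert-butyl; no step is computed for that pair, but compound 1 gives 1.7% while compound 2 gives 12.2%, the second beyond the scatter of the first. Compound 4 is therefore expected to step upward from compound 3 by a number 10 percentage points higher from compound 3 to compound 4 (within the scatter), mainly because compound 2 gives 12.2% with the same group on its amide nitrogen. The estimate for compound 4 in this assay is 10%, with a range from 0% to 25%.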

Compound 4, a percentage reported as inhibition, in the whole organism at one dose (the size of the read-out at that dose, not a potency): 15.7%
The estimate for compound 4 lay 5.7 percentage points below the measured number, within the range that was stated.
By their numbers in this assay, from the lowest: compounds 3 and 1 (each within the scatter of the next); then compounds 2 and 4 (each within the scatter of the next).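

In this assay, 2,6-dimethylphenyl in place of 4-bromophenyl on the amide-type nitrogen now has a measured step on the core bearing tert-butyl: a number 15.7 percentage points higher from compound 3 to compound 4 (beyond the scatter). It is the first step among these compounds to lie beyond the scatter, so the group on this nitrogen moves the read-out here, whereas the one earlier step, at the aromatic carbon, did not. With 2,6-dimethylphenyl on the amide-type nitrogen, tert-butyl in place of methyl on the aromatic carbon gives a number 3.5 percentage points higher from compound 2 to compound 4 (within the scatter), and the exchange at that carbon reads the same with either group on the nitrogen: the same change on two cores in this assay, a number 1.7 percentage points lower (within the scatter) from compound 1 to compound 3 and a number 3.5 percentage points higher (within the scatter) from compound 2 to compound 4, 5.2 percentage points apart, within the scatter of two such steps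

As far as these compounds go, whether the step at the amide-type nitrogen goes with the loss of the bromine or with the two methyl groups stays open, and 4-methylphenyl or 2,6-dichlorophenyl on that nitrogen would help to tell these apart. Also open is how a pyridine ring in place of the phenyl ring would read in this assay, and how any of these compounds would read at a dose other than the one given.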